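The source may hold more compounds than are shown below. What is called first, only, known or untested is meant among the compounds shown, and "the series" means these compounds.

Compound 1 `CC(C)Oc1cc(-c2ccccc2)nc2ccccc12`: > 10 ug/mL
Compound 2 `CCCOc1cc(-c2ccccc2)nc2ccccc12`: > 10 ug/mL

Both entries come from a functional assay on A549 cells (Homo sapiens) for cytotoxicity; on this read-out higher numbers stand for an effect only at larger amounts of compound and lower numbers for an effect already at smaller amounts. Compound 2 gives > 10 ug/mL, which is a limit of the assay and not a number. Compound 1 gives > 10 ug/mL, which is also a limit. The whole picture so far is therefore (the limit of > 10 ug/mL in this assay, at which 2 of the 2 values shown sit).

Compound 3 `CCCCOc1cc(-c2ccccc2)nc2ccccc12` turns the propyl group of compound 2 into butyl: methyl in place of hydrogen on a saturated chain carbon, three bonds along the chain from an oxygen on an aromatic ring. Going by the values given here, the only measured step that bears on this change is a step that the two limits leave unreadable from compound 1 to compound 2, which also alters the chain on the oxygen but gives no size to build on. With no readable step, no shift beyond the scatter is expected, and no direction can be favoured. The expected change is a step that the limit leaves unreadable from compound 2 to compound 3. Compound 3 is estimated at 12 ug/mL, with an expected range from 5 ug/mL to 30 ug/mL, and it may well be reported only as a limit.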

Compound 3, half-maximal effective concentration: > 10 ug/mL
Compound 3: only a limit was reported; the forecaster's own chance of this, stated with the estimate: 75%; the middle value does not contradict the limit.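

The steps from compound 1 and compound 2 to compound 3 cannot be read, as all three compounds give a limit and not a number: the limit of > 10 ug/mL in this assay, at which 3 of the 3 values shown sit. The compounds shown leave open whether the isopropyl, propyl and butyl compounds differ at all in this assay.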